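Hydroxy in place of methyl on the shared core

A few compounds are considered here, and "the series" means these few. Any claim that something is new, unique, unknown or untested is made for them only; others in the source may bear on it.

In a functional assay on HCT-116 cells (Homo sapiens) for inhibition, read by MTT assay, with a stated time of 48 h (on this read-out lower numbers stand for stronger inhibition and higher numbers for weaker inhibition), compound 3 (`C/C=C/C(=O)N(Cc1ccc(OC)c(C)c1)c1cc(OC)c(OC)c(OC)c1`) gives 23500 nM, the highest number of the three measured and so the weakest inhibitor so far. Compound 2 (`C/C=C/C(=O)N(Cc1ccc(OC)c(Br)c1)c1cc(OC)c(OC)c(OC)c1`) gives 2800 nM, and compound 1 (`CCC/C=C/C(=O)N(Cc1ccc(OC)c(O)c1)c1cc(OC)c(OC)c(OC)c1`) gives 95 nM. The next analogue, compound 4 (`C/C=C/C(=O)N(Cc1ccc(OC)c(O)c1)c1cc(OC)c(OC)c(OC)c1`), departs from compound 3 by hydroxy in place of methyl on an aromatic carbon, or 4-methoxy-3-methylphenyl to 3-hydroxy-4-methoxyphenyl. Going by the values given here, the only measured step at this carbon is an 8.4-fold higher number from compound 2 to compound 3 (0.92 log units; beyond the scatter), with methyl in place of bromo, and it lies beyond the scatter. Compound 1 already carries the 3-hydroxy-4-methoxyphenyl group, on a different acyl chain, and its 95 nM is the closest guide, although no measurement isolates the effect of that chain. In this assay, a step to a lower number is therefore expected, larger than the one from bromo to methyl, with an estimate of a 160-fold lower number from compound 3 to compound 4 (2.19 log units; beyond the scatter). For compound 4 the estimated value is 150 nM, with an expected range of 30 nM to 900 nM.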

Compound 4, half-maximal inhibitory concentration: 55 nM
Compound 4: middle estimate off by 2.7-fold (0.44 log units), on the high side; the range from low to high includes it.
By their numbers in this assay, from the lowest: compounds 4 and 1 (each within the scatter of the next); then compound 2; then compound 3.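

In this assay, hydroxy on this aromatic carbon, ortho to a methoxy group, gives much lower numbers than either group measured there before: a 430-fold lower number from compound 3 to compound 4 (2.63 log units; beyond the scatter) against methyl and a 51-fold lower number from compound 2 to compound 4 (1.71 log units; beyond the scatter) against bromo, both larger than the earlier 8.4-fold higher number from compound 2 to compound 3 (0.92 log units; beyond the scatter) for methyl in place of bromo. No supporting evidence accompanies these steps, so neither the hydrogen-bond donor nor the hydrogen-bond acceptor that enters with hydroxy can be tied to them. With the 3-hydroxy-4-methoxyphenyl group held, hydrogen in place of ethyl on the chain gives a 1.7-fold lower number from compound 1 to compound 4 (0.24 log units; within the scatter), so the two acyl chains cannot be told apart here.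

Open, from the compounds shown here alone, is whether an amine or a fluoro group at this carbon would come close to hydroxy. Also open, going by these compounds, is whether an acyl chain longer than that of compound 1 stays within the scatter of compound 4.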